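A few compounds are considered here, and "the series" means these few. Any claim that something is new, unique, unknown or untested is made for them only; others in the source may bear on it.

Compound 1, `Cc1ccc(C(=O)Nc2cccc(-c3oc4cc(-c5ccc(F)cc5)ccc4c(=O)c3O)c2)cc1`, is the starting point of this short series. In a functional assay on A549 cells (Homo sapiens) for antiproliferative activity, read by CCK-8 assay, with a stated time of 72 h (a higher number here means a weaker inhibitor, a lower number a stronger inhibitor), compound 1 gives 6910 nM. Compound 2, `O=C(Nc1cccc(-c2oc3cc(-c4ccc(F)cc4)ccc3c(=O)c2O)c1)c1ccc([N+](=O)[O-])cc1`, carries a nitro group in place of the methyl group of compound 1, and in this assay compound 2 gives 2440 nM. The change gives a 2.8-fold lower number from compound 1 to compound 2 (0.45 log units; beyond the scatter). Going by the values given here, of the two numbers measured so far, compound 2 holds the lower one, with compound 1 the nearest neighbour at a higher value.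

The next compound, compound 3, is `O=C(Nc1cccc(-c2oc3cc(-c4ccc(F)cc4)ccc3c(=O)c2O)c1)c1ccc(-c2ccccc2)cc1`. Relative to compound 2 the change is phenyl in place of nitro on an aromatic carbon. Among the compounds with values here, only the step from compound 1 to compound 2 bears on this, since it alters the same aromatic carbon, and it was modest; the replacement there, methyl for nitro, differs from the present one, nitro for phenyl, so it gives a direction only loosely. Compound 3 is therefore expected to land near compound 2 in this assay, with the step estimated as a 1.4-fold higher number from compound 2 to compound 3 (0.16 log units; within the scatter). The estimate for compound 3 is 3500 nM, within a range of 1200 nM to 10000 nM.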

Compound 3, half-maximal inhibitory concentration: > 100000 nM
Compound 3 gave a limit, no number; the forecaster's own chance of this, stated with the estimate: 5%; middle value at least 28-fold (1.45 log units) from the limit.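

In this assay, going by these compounds alone, the aromatic carbon para to a large group had so far carried only methyl and nitro, with a modest shift between them, so the earlier compounds gave no sign that a change here could move the result much further. Phenyl does exactly that, giving an at least 40-fold higher number from compound 2 to compound 3 (1.61 log units; beyond the scatter) and, against the methyl group, an at least 14-fold higher number from compound 1 to compound 3 (1.16 log units; beyond the scatter), so this position is far more sensitive to what it carries than the first pair suggested. The reading for compound 3 is a limit of the assay and not a number: the limit of > 100000 nM in this assay, at which 1 of the 3 values shown sits.

The compounds shown do not tell whether an amine, a carboxylic acid or a longer chain such as butyl at this carbon would stay near compound 2 or fall away like compound 3. Nor do they tell what about the phenyl group produces this step.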